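Alkynyl uracils: 4-bromophenyl in place of butyl

The source may hold more compounds than are shown below. What is called first, only, known or untested is meant among the compounds shown, and "the series" means these compounds.

In a functional assay on L1210 cells (Mus musculus) for antiproliferative activity, read by MTT assay, with a stated time of 2 days (on this read-out higher numbers stand for weaker inhibition and lower numbers for stronger inhibition), compound 2 `CCCCC#Cc1cn(C/C=C\CN2C(=O)c3ccccc3C2=O)c(=O)[nH]c1=O` gives 109000 nM, the highest of the three numbers in hand. Going by the values given here, compound 1 `CCCCCCCCC#Cc1cn(C/C=C\CN2C(=O)c3ccccc3C2=O)c(=O)[nH]c1=O` gives 45000 nM and compound 3 `CCCCCCC#Cc1cn(C/C=C/CN2C(=O)c3ccccc3C2=O)c(=O)[nH]c1=O` gives 43000 nM; compound 3 differs from both in two places, so no single step connects it. The unmeasured compound 4 `O=C1c2ccccc2C(=O)N1C/C=C\Cn1cc(C#Cc2ccc(Br)cc2)c(=O)[nH]c1=O` differs from compound 2 by 4-bromophenyl in place of butyl on a triple-bonded carbon. Among the compounds with values here, the only step touching the same part of the molecule is a 2.4-fold higher number from compound 1 to compound 2 (0.38 log units; beyond the scatter), a modest rise when butyl is lost. On these data alone, whether 4-bromophenyl behaves like the butyl it replaces or like an added substituent is untested, but the substituent on the triple-bonded carbon appears to matter only modestly. Compound 4 is therefore expected to return roughly to the level of compound 1, a step of a 2.4-fold lower number from compound 2 to compound 4 (0.38 log units; beyond the scatter), i.e. an estimated 45000 nM with a range of 15000 nM to 135000 nM.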

Compound 4, half-maximal inhibitory concentration: 448000 nM
Beside the measured number, compound 4's estimate is 10-fold (1.00 log units) below it; measured number outside the range, above it.
By their numbers in this assay, from the lowest: compounds 3 and 1 (each within the scatter of the next); then compound 2; then compound 4.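

In this assay, 4-bromophenyl on the triple-bonded carbon gives weaker inhibition than either chain it replaces, with a 4.1-fold higher number from compound 2 to compound 4 (0.61 log units; beyond the scatter) for butyl and a 10-fold higher number from compound 1 to compound 4 (1.00 log units; beyond the scatter) for octyl. This position therefore responds to the kind of group as well as to the chain length seen earlier, and the aromatic ring does not stand in for an alkyl chain here. No measurement in hand explains this change.

On these data alone, whether the ring or the bromine carries the loss remains open. Also open, as far as these compounds go, is how plain phenyl or a hydroxyalkyl chain on the same carbon would compare.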